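Compound 4: swapping chloro for methoxy

The source may report more compounds than this note shows. Statements on the series, on what has been measured and on what is new or still open speak of the compounds shown alone.

- compound 1 `COc1cc(/C=C/C(=O)c2cccc(-n3cc(-c4ccc(Cl)cc4)[nH]c3=O)c2)cc(OC)c1OC` gives 31400 nM
- compound 2 `COc1cc(/C=C/C(=O)c2cccc(-n3cc(-c4ccccc4)[nH]c3=O)c2)ccc1O` gives 3760 nM
- compound 3 `O=C(/C=C/c1cccc(O)c1)c1cccc(-n2cc(-c3ccccc3)[nH]c2=O)c1` gives 11100 nM

In a functional assay on SK-OV-3 cells (Homo sapiens) for inhibition (a lower number here means a stronger inhibitor of growth, a higher number a weaker inhibitor of growth), compound 1 has the highest of these three numbers, and its gaps to compound 2 and compound 3 both lie beyond the scatter. Compound 4 `COc1ccc(-c2cn(-c3cccc(C(=O)/C=C/c4cc(OC)c(OC)c(OC)c4)c3)c(=O)[nH]2)cc1` differs from compound 1 in one place, with methoxy in place of chloro on an aromatic carbon, para to a large group (methoxy in place of chloro on an aromatic carbon). Going by the values given here, only one measured step links two compounds differing in one place, namely a 3.0-fold higher number from compound 2 to compound 3 (0.47 log units; beyond the scatter) and it lies at another place in the molecule. Among the compounds with values here, it shows that one change can shift the number modestly, but no measured step exchanges chloro for methoxy. With compound 1 at 31400 nM as the highest number, a slight lean towards a lower number is expected in this assay but no clear step. The estimate amounts to a 1.4-fold lower number from compound 1 to compound 4 (0.15 log units; within the scatter) and this expected step stays within the scatter. The estimated value for compound 4 is 22000 nM with 8000 nM to 60000 nM as its expected range.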

Compound 4, concentration for 50% growth inhibition: 4600 nM
For compound 4 the middle estimate is 4.8-fold (0.68 log units) above the measured one; measured number below the stated range.
By their numbers in this assay, from the lowest: compounds 2 and 4 (each within the scatter of the next); then compound 3; then compound 1.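

In this assay the change from 4-chlorophenyl to 4-methoxyphenyl gives a 6.8-fold lower number from compound 1 to compound 4 (0.83 log units; beyond the scatter). Going by these compounds alone, this is the first measured step at this place, on an aromatic carbon para to a large group, and it shows that a single exchange here moves the number beyond the scatter, which the step at another place in the molecule could not show. Nothing available accounts for the shift through any measured property of either group.

As far as these compounds go, how an amine, a hydroxy group or a longer chain such as ethoxy would fare on this carbon remains open. Also open, from the compounds shown here alone, is where the core of compound 1 would fall with hydrogen at this place, which would help tell whether the step comes from chloro, from methoxy or from both.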